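This account rests on a few compounds, and the source may have more. Where it says the series, first, only, none or still open, it means among the compounds named here.

Measured so far:
compound 1 `CN(CC1CCC/C(=C\c2ccc(S(C)(=O)=O)cc2)C1=O)c1ccccc1`, which in a functional assay on the whole organism (Ear, strain Kunming) for inhibition, with Mus musculus as the target, with stated times of 1 h and 30 min, at a dose of 200 mg/kg by the oral route (a higher number here means more inhibition at the dose given (going by the name of the read-out), a lower number less inhibition), gives 46.9%;
compound 2 `Cc1ccc(N(C)CC2CCC/C(=C\c3ccc(S(C)(=O)=O)cc3)C2=O)cc1`, which in this assay gives 27%;
compound 3 `COc1ccc(C2(O)/C(=C/c3ccccc3)CCCC2CN(C)c2ccccc2)cc1`, which in this assay gives 26.5%.

Compound 2 differs from compound 1 in one place only: methyl in place of hydrogen on an aromatic carbon. This change made the step of a number 19.9 percentage points lower from compound 1 to compound 2 (beyond the scatter), a drop that is beyond the scatter. Compound 3 has a different core; the difference between the two cores is not broken down here. Compound 3 and compound 2 give numbers within the scatter of each other, so nothing can be said about their order.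

Compound 4 `COc1ccc(C2(O)/C(=C/c3ccccc3)CCCC2CN(C)c2ccc(C)cc2)cc1` has not yet been measured. It differs from compound 3 by methyl in place of hydrogen on an aromatic carbon, the same change, at the same kind of place, that separates compound 1 from compound 2. If that change acts alike on the core of compound 3, a step of about the same size is expected, a number 14.5 percentage points lower from compound 3 to compound 4 (beyond the scatter). This expectation rests on one measured pair only, and the core of compound 3 is not the core of compound 1, so the range is kept wide. For compound 4 the estimate in this assay is 12%, with a range from 0% to 28%.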

Compound 4, a percentage reported as inhibition, in the whole organism at one dose (the size of the read-out at that dose, not a potency): 26.5%
For compound 4 the middle estimate is 14.5 percentage points below the measured one, and the stated range covers the measured number.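

In this assay, the change from phenyl to 4-methylphenyl gives no change at the digits printed from compound 3 to compound 4 (within the scatter). The same methyl therefore does not carry the same step from one core to the other, so a step measured on the core of compound 1 cannot simply be transferred to the core of compound 3: the same change on two cores in this assay, a number 19.9 percentage points lower (beyond the scatter) from compound 1 to compound 2 and no change at the digits printed (within the scatter) from compound 3 to compound 4, 19.9 percentage points apart, beyond the scatter of two such steps

For the compounds shown here, this does not show which of the differences between the two cores matters, or why the steps differ, and it rests on only one pair per core, each compound tested at a single dose.

Still open, from the compounds shown here alone, is how other groups at this place, such as a chlorine atom or a longer chain like ethyl, would act on either core. Also open, going by these compounds, is what the methyl would do on a core carrying only some of the differences between the two, for example the carbonyl of compound 1 together with the unsubstituted phenyl of compound 3.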